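The source may hold more compounds than are shown below. What is called first, only, known or untested is meant among the compounds shown, and "the series" means these compounds.

Compound 1 `COc1cc(/C=C2\CCC/C(=C\c3ccccc3[N+](=O)[O-])C2=O)cc(Br)c1OC`: 8.99 ug/mL
Compound 2 `COc1cccc(/C=C2\CCC/C(=C\c3cccc([N+](=O)[O-])c3)C2=O)c1OC`: 5.59 ug/mL
Compound 3 `COc1cc(/C=C2\CCC/C(=C\c3cccc([N+](=O)[O-])c3)C2=O)cc(Br)c1OC`: 13.9 ug/mL

In a functional assay on MDA-MB-231 cells (Homo sapiens) for cytotoxicity, read by MTT assay (on this read-out higher numbers stand for weaker inhibition and lower numbers for stronger inhibition), compound 3 gives 13.9 ug/mL, the highest of the three numbers. Its nearest neighbour is compound 1, reached by the step of a 1.5-fold higher number from compound 1 to compound 3 (0.19 log units; within the scatter), which lies within the scatter. Among the compounds with values here, compound 2 gives 5.59 ug/mL, a lower number that lies beyond the scatter; no single-change step links it to compound 3.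

Compound 4 `CCOc1c(Br)cc(/C=C2\CCC/C(=C\c3cccc([N+](=O)[O-])c3)C2=O)cc1OC` differs from compound 3 by methyl in place of hydrogen on a saturated chain carbon bound to an oxygen on an aromatic ring. Within the data shown here, none of the measured steps touches this kind of change; the only measured step, a 1.5-fold higher number from compound 1 to compound 3 (0.19 log units; within the scatter), moves the nitro group and tells nothing about lengthening the alkoxy chain. With no guidance from the data, the expected step in this assay is no change at the digits printed from compound 3 to compound 4 (within the scatter). Compound 4 is therefore estimated at 13.9 ug/mL, with a range from 7 ug/mL to 28 ug/mL.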

Compound 4, half-maximal inhibitory concentration: 19.3 ug/mL
Compound 4: middle estimate off by 1.4-fold (0.14 log units), on the low side, within the range that was stated.
By their numbers in this assay, from the lowest: compounds 2, 1, 3 and 4 (each within the scatter of the next, the first and the last beyond it).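

In this assay, the change from methoxy to ethoxy gives a 1.4-fold higher number from compound 3 to compound 4 (0.14 log units; within the scatter), so the two compounds cannot be told apart on this read-out. Within the data shown here, this is the first look at the chain on this oxygen, since the earlier step only moved the nitro group, and one added methyl here makes no difference beyond the scatter. No outside evidence bears on this result.

Still open, going by these compounds, is whether a longer chain such as butoxy, or a chain ending in an amine, would give a number beyond the scatter.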